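Swapping the hydrazone arm on a thiosemicarbazide series

A few compounds are considered here, and "the series" means these few. Any claim that something is new, unique, unknown or untested is made for them only; others in the source may bear on it.

In a functional assay on HT-29 cells (Homo sapiens) for cytotoxicity, read by sulforhodamine B assay (on this read-out higher numbers stand for weaker inhibition of growth and lower numbers for stronger inhibition of growth), compound 2, `CC1=CC[C@@H]([C@@](C)(O)CCCC(C)(C)NC(=S)N/N=C\c2ccc(O)cc2)CC1`, gives 8150 nM, the lowest of the three numbers in hand. Its nearest neighbour is compound 3, `CC1=CC[C@@H]([C@@](C)(O)CCCC(C)(C)NC(=S)N/N=C\c2ccc([N+](=O)[O-])cc2)CC1`, which gives 12300 nM; the step of a 1.5-fold higher number from compound 2 to compound 3 (0.18 log units; within the scatter) is within the scatter, so the two cannot be told apart. The plain thiosemicarbazide, compound 1, `CC1=CC[C@@H]([C@@](C)(O)CCCC(C)(C)NC(=S)NN)CC1`, gives 49400 nM, and the step of a 6.1-fold lower number from compound 1 to compound 2 (0.78 log units; beyond the scatter) shows that attaching the aromatic hydrazone arm is what lowered the number.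

Compound 4, `CC1=CC[C@@H]([C@@](C)(O)CCCC(C)(C)NC(=S)N/N=C(/C)c2ccccc2)CC1`, differs from compound 2 at the same arm: a group of 9 heavy atoms (8 carbon, 1 nitrogen; one six-membered aromatic ring of carbon only) in place of a group of 9 heavy atoms (7 carbon, 1 nitrogen, 1 oxygen; one six-membered aromatic ring of carbon only), on an amide-type nitrogen. The aromatic ring and the imine are kept; the hydroxy is gone and a methyl sits on the imine carbon instead of a hydrogen. For the measured compounds named here, two measured steps bear on this. The step of a 6.1-fold lower number from compound 1 to compound 2 (0.78 log units; beyond the scatter) says the arm as a whole matters, and the step of a 1.5-fold higher number from compound 2 to compound 3 (0.18 log units; within the scatter) says that changing the group on the ring, from hydroxy to nitro, made no difference beyond the scatter. Since compound 4 keeps the arm and only reshapes it, the expected step of a 1.2-fold higher number from compound 2 to compound 4 (0.09 log units; within the scatter) is none beyond the scatter. Compound 4 is therefore estimated at 10000 nM, with a range from 4000 nM to 25000 nM.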

Compound 4, concentration for 50% growth inhibition: 28400 nM
Compound 4: the middle estimate sits 2.8-fold (0.45 log units) below what was measured, outside the stated range (above it).
By their numbers in this assay, from the lowest: compounds 2 and 3 (each within the scatter of the next); then compounds 4 and 1 (each within the scatter of the next).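

For the compounds shown here, the arm is less forgiving than the earlier compounds suggested. Swapping hydroxy for nitro on the ring stayed within the scatter, but in this assay there is a 3.5-fold higher number from compound 2 to compound 4 (0.54 log units; beyond the scatter) when the hydroxy goes and a methyl takes the hydrogen's place on the imine carbon. Keeping an aromatic ring and an imine is therefore not enough to hold the gain seen with compound 2, since a 1.7-fold lower number from compound 1 to compound 4 (0.24 log units; within the scatter) leaves compound 4 indistinguishable from the plain thiosemicarbazide, and no measurement at hand gives a reason for this.

On these data alone, compound 4 differs from compound 2 in two features of one arm, so it remains open whether losing the hydroxy, adding the imine methyl, or both together account for the step; an arm with the hydroxy and the imine methyl together, or one with an unsubstituted ring and a hydrogen on the imine carbon, would separate these. As far as these compounds go, how an amine on the ring or an ethyl on the imine carbon would read in this assay is also open.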